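From dimethylamino to trifluoromethyl on the benzyl amide

The compounds below may be only part of what the source reports. "The series", "measured", "known", "first", "only" and "open" are said of these compounds alone.

Three amides built on a shared core offer very little to work from. In a functional assay on MCF7 cells (Homo sapiens) for cytotoxicity, read by MTT assay, with a stated time of 72 h (on this read-out higher numbers stand for weaker inhibition and lower numbers for stronger inhibition), compound 1 (`N[C@H]1CC[C@H](Nc2c(C(=O)NCc3ccco3)nc(Br)c3cccnc23)CC1`) carries the entry "not determined" (no result reported) with no result reported, and compound 2 (`N[C@H]1CC[C@H](Nc2c(C(=O)NCc3ccc(Cl)cc3Cl)nc(Br)c3cccnc23)CC1`) carries the entry "not determined" (no result reported) in the same way. Among the measured compounds shown here, compound 3 (`CN(C)c1ccc(CNC(=O)c2nc(Br)c3cccnc3c2N[C@H]2CC[C@H](N)CC2)cc1`) gives 5000 nM in this assay and so stands alone, the one number in the set, with nothing to rank it against.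

Compound 4 (`N[C@H]1CC[C@H](Nc2c(C(=O)NCc3cccc(C(F)(F)F)c3)nc(Br)c3cccnc23)CC1`) keeps the shared core and changes one group, with 3-(trifluoromethyl)phenyl in place of 4-(dimethylamino)phenyl on a saturated chain carbon bound to an amide-type nitrogen. Put one bond further out, this is 4-(dimethylamino)benzyl giving way to 3-(trifluoromethyl)benzyl.

For the measured compounds named here, no measured pair shows what a change at this place does in this assay and the data therefore suggest neither a size nor a direction. The expectation rests on compound 3 at 5000 nM alone and foresees no shift beyond the usual scatter. The expected step is a 1.3-fold lower number from compound 3 to compound 4 (0.10 log units; within the scatter) and this estimate carries wide uncertainty. In this assay the estimated half-maximal inhibitory concentration for compound 4 is 4000 nM with an expected range of 1300 nM to 12000 nM around it.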

Compound 4, half-maximal inhibitory concentration: 15000 nM
The estimate for compound 4 lay 3.8-fold (0.57 log units) below the measured number; the whole stated range lies below it.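

In this assay the place on a saturated chain carbon bound to an amide-type nitrogen now proves able to move the read-out: the change gives a 3.0-fold higher number from compound 3 to compound 4 (0.48 log units; beyond the scatter) and so takes the number in the weaker direction. Among the compounds shown here, this is the first comparison the set allows, since the entries for compound 1 and compound 2 hold no number and any steps involving them cannot be read. For the compounds shown here, the single step swaps 4-(dimethylamino)phenyl for 3-(trifluoromethyl)phenyl, so the identity of the group and its location on the ring change together, and the step cannot assign the loss to either one; nothing available bears on why the number rose.

The compounds shown leave open whether 4-(trifluoromethyl)phenyl or 3-(dimethylamino)phenyl at this place would track the group or its location on the ring. They also leave open whether a plain phenyl, a carboxylic acid or a longer chain between the amide nitrogen and the ring would fall nearer compound 3 or compound 4 on this read-out.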